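An isopropyl group added to compound 3

The source may hold more compounds than are shown below. What is called first, only, known or untested is meant among the compounds shown, and "the series" means these compounds.

In a functional assay on A-375 cells (Homo sapiens) for antiproliferative activity, read by trypan blue exclusion and crystal violet staining, with a stated time of 72 h (a lower number here means a stronger inhibitor, a higher number a weaker inhibitor), compound 3 `CCCC(=O)NC(c1ccccc1)c1cc(Cl)c2cccnc2c1O` gives 130 nM, the lowest of the three numbers, with compound 1 `CCCCOc1ccnc2c(O)c(CNC(=O)C3CCCCC3)ccc12` at 540 nM and compound 2 `O=C(NCc1ccc2cccnc2c1O)C1CCCCC1` at 910 nM. Compound 4 `CCCC(=O)NC(c1ccc(C(C)C)cc1)c1cc(Cl)c2cccnc2c1O` carries isopropyl in place of hydrogen on an aromatic carbon, para to a large group: isopropyl in place of hydrogen on an aromatic carbon. Among the measured compounds shown here, no measured step touches this phenyl. The only one that bears on the change, and only loosely, is a 1.7-fold higher number from compound 1 to compound 2 (0.23 log units; within the scatter), where hydrogen replaces butoxy at a different place on the core. On that single step, no shift beyond the scatter is expected, and the estimated change is a 1.2-fold higher number from compound 3 to compound 4 (0.06 log units; within the scatter). For compound 4 the expected value is 150 nM, within an estimated range of 50 nM to 450 nM.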

Compound 4, half-maximal inhibitory concentration: 120 nM
Beside the measured number, compound 4's estimate is 1.3-fold (0.10 log units) above it; the measured number falls inside the stated range.
By their numbers in this assay, from the lowest: compounds 4 and 3 (each within the scatter of the next); then compounds 1 and 2 (each within the scatter of the next).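

The earlier step touched only the core, whereas this one reaches the phenyl: in this assay, phenyl to 4-isopropylphenyl gives a 1.1-fold lower number from compound 3 to compound 4 (0.03 log units; within the scatter). At this place on the six-membered aromatic ring, an isopropyl group therefore leaves the number within the scatter, so this added bulk of carbon does not cost activity against these cells. The data offer no measured basis for explaining this flat result. As far as these compounds go, whether a carboxylic acid, an amine or a longer chain at this place would also leave the number unchanged remains open.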